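Methylsulfanyl on the urea aryl ring of compound 3

A few compounds are considered here, and "the series" means these few. Any claim that something is new, unique, unknown or untested is made for them only; others in the source may bear on it.

Measured compounds:
Compound 1, `O=C(Nc1ccc(F)cc1)N[C@H]1CC[C@H](Oc2ccc(F)cc2)CC1`, 20000 nM
Compound 2, `O=C(Nc1ccccc1[N+](=O)[O-])N[C@H]1CC[C@H](Oc2ccc(F)cc2)CC1`, 3500 nM
Compound 3, `O=C(Nc1ccccc1)N[C@H]1CC[C@H](Oc2ccc(F)cc2)CC1`, 20000 nM

All three share the same core and were tested in a functional assay on CRL2813 cells (Homo sapiens) for cytotoxicity, read by sulforhodamine B assay, with a stated time of 5 days; a lower number here means a stronger inhibitor, a higher number a weaker inhibitor. Compound 3 stands level with compound 1, and together they give the highest numbers of the three; compound 2 is the furthest away, with a 5.7-fold higher number from compound 2 to compound 3 (0.76 log units; beyond the scatter). Swapping fluoro for hydrogen on the urea aryl ring gave no change at the digits printed from compound 1 to compound 3 (within the scatter), so that ring tolerates a small change without moving the number.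

Compound 4, `CSc1cccc(NC(=O)N[C@H]2CC[C@H](Oc3ccc(F)cc3)CC2)c1`, differs from compound 3 by a single change: methylsulfanyl in place of hydrogen on an aromatic carbon. Going by the values given here, no measured step introduces a methylsulfanyl, so the nearest guides are the two steps above. The hydrogen-to-fluoro comparison suggests that a small group on this ring can leave the number unchanged, while the nitro step shows that a group on the same ring can lower it modestly. Taken together, compound 4 is expected to sit near compound 3, with at most a small step: a 1.3-fold lower number from compound 3 to compound 4 (0.12 log units; within the scatter). The estimate for compound 4 is therefore 15000 nM, within a range from 6000 nM to 30000 nM.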

Compound 4, half-maximal inhibitory concentration: 11100 nM
For compound 4 the middle estimate is 1.4-fold (0.13 log units) above the measured one; the measured number falls inside the stated range.
By their numbers in this assay, from the lowest: compound 2; then compounds 4, 1 and 3 (each within the scatter of the next).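

In this assay, methylsulfanyl is the only group shown meta to a large group on this ring, and adding it gives a 1.8-fold lower number from compound 3 to compound 4 (0.26 log units; within the scatter) so this added sulfur-bearing group leaves compound 4 level with the unsubstituted ring of compound 3. The swap from the fluorinated ring gives a 1.8-fold lower number from compound 1 to compound 4 (0.26 log units; within the scatter) and so compounds 1, 3 and 4 form one cluster, even though the three rings differ, whereas the comparison with the nitro compound gives a 3.2-fold higher number from compound 2 to compound 4 (0.50 log units; beyond the scatter) and compound 2 alone stands apart among the four. Nothing measured here explains this difference between compound 2 and the other three compounds.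

The compounds shown leave open whether any other group at this same place, such as an amine, a carboxylic acid or a longer chain like ethylsulfanyl, would separate from this cluster as the 2-nitrophenyl compound does. They also leave open whether methylsulfanyl on another carbon of this ring, or nitro at the place methylsulfanyl occupies here, would give a different number.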